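Fluoro to trifluoromethyl on the aromatic ring

This account rests on a few compounds, and the source may have more. Where it says the series, first, only, none or still open, it means among the compounds named here.

Measured in a functional assay on MCF7 cells (Homo sapiens) for antiproliferative activity, with a stated time of 5 days; a lower number here means a stronger inhibitor, a higher number a weaker inhibitor:
Compound 1 `CCCCc1ccc2[nH]c(-c3ccc(C)cc3)c(C=O)c2c1`: 54 nM
Compound 2 `CCCCc1ccc2[nH]c(-c3ccc(F)cc3)c(C=O)c2c1`: 200 nM

Compound 2, at 200 nM, holds the higher of the two numbers in this assay, which makes it the weaker inhibitor of the pair. The next structure is compound 3 `CCCCc1ccc2[nH]c(-c3ccc(C(F)(F)F)cc3)c(C=O)c2c1`, with trifluoromethyl in place of fluoro on an aromatic carbon, para to a large group: trifluoromethyl in place of fluoro on an aromatic carbon.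

Within the data shown here, one measured step bears on this place: a 3.7-fold higher number from compound 1 to compound 2 (0.57 log units; beyond the scatter), a modest change beyond the scatter, with fluoro in place of methyl. It shows that the number moves with the group at this place, but this single pair gives no direct reading on trifluoromethyl. Like the methyl of compound 1 at 54 nM, the entering group joins the ring through carbon, so a shift toward a lower number is expected, smaller than the measured step and with limited confidence in its direction. The expected step is a 1.8-fold lower number from compound 2 to compound 3 (0.26 log units; within the scatter). For compound 3 the estimated value is 110 nM, with an expected range from 35 nM to 350 nM.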

Compound 3, half-maximal inhibitory concentration: 66 nM
Compound 3: middle estimate off by 1.7-fold (0.22 log units), on the high side; low and high end bracket the measured number.
By their numbers in this assay, from the lowest: compounds 1 and 3 (each within the scatter of the next); then compound 2.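

In this assay the step of a 3.0-fold lower number from compound 2 to compound 3 (0.48 log units; beyond the scatter) is modest but beyond the scatter, and it gives this place on the aromatic ring a direct reading for trifluoromethyl against fluoro, which the earlier pair could not provide. The step of a 1.2-fold higher number from compound 1 to compound 3 (0.09 log units; within the scatter) lies within the scatter, so trifluoromethyl and methyl cannot be separated at this place, and compound 2 with its fluoro is the one of the three whose number stands apart from the other two. No measurement available here accounts for this pattern, so the reading stays purely empirical.

On these data alone, the three compounds cover only methyl, fluoro and trifluoromethyl on this ring carbon, so it remains open how a methoxy group, an amine, a carboxylic acid or a longer chain would read at the same place, and whether the fluoro result is a lone exception or part of a wider trend. The butyl chain and the carbonyl group are identical across the series, so nothing shown tells whether this reading would hold with either of them changed.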